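The source may report more compounds than this note shows. Statements on the series, on what has been measured and on what is new or still open speak of the compounds shown alone.

Compound 2 `CC(C)=CCCC1=CC[C@@H](C(=O)N(C)C)[C@H](c2ccccc2)C1` carries a dimethylcarbamoyl group on the shared core. In an assay on isolated protein for inhibition of Apoptosis regulator Bcl-2 (Homo sapiens), read by fluorescence polarization, with stated times of 5 min and 10 min (on this read-out higher numbers stand for weaker inhibition and lower numbers for stronger inhibition), compound 2 reaches only the limit of the measurement, > 23000 nM, so no number is known for it. Its mirror image, compound 3 `CC(C)=CCCC1=CC[C@H](C(=O)N(C)C)[C@@H](c2ccccc2)C1`, also sits at the limit in this assay, with > 23000 nM. The step that the two limits leave unreadable from compound 2 to compound 3 therefore cannot be read, because the fact that compounds 2 and 3 differ only in the configuration as drawn leaves the two limits facing each other. Compound 1 `CC(C)=CCCC1=CC[C@H](C(=O)N(C)O)[C@@H](c2ccccc2)C1`, which carries hydroxy rather than methyl on the amide-type nitrogen, gives 2100 nM in this assay, and the step of an at least 10-fold higher number from compound 1 to compound 3 (1.03 log units; beyond the scatter) shows that replacing the hydroxy by methyl costs a large amount of binding.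

Compound 4 `CON(C)C(=O)[C@@H]1CC=C(CCC=C(C)C)C[C@H]1c1ccccc1` is compound 2 with the change (methoxy in place of methyl on an amide-type nitrogen). The measured steps speak only indirectly to this change: the hydroxy of compound 1 is not restored, only a methoxy enters, and the mirror-image pair shows no readable step. Given (the limit of > 23000 nM in this assay, at which 2 of the 3 values shown sit), compound 4 is expected to remain close to the limit, with at most a modest gain from the added acceptor. The estimate for compound 4 in this assay is 20000 nM, between 5000 nM and 60000 nM, and the expected step of an at least 1.1-fold lower number from compound 2 to compound 4 (0.06 log units; that floor lies within the scatter) is small.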

Compound 4, inhibition constant: > 23000 nM
Compound 4: no number, only a limit (the forecaster's own chance of this, stated with the estimate: 55%); at least 1.1-fold (0.06 log units) between middle value and limit.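

Like compound 2, compound 4 reaches only a limit in this assay, > 23000 nM, so no step from compound 2 to compound 4 can be read. The compounds shown leave open whether methoxy in place of methyl on the amide-type nitrogen changes the binding at all, and how weak compound 2 and compound 4 really are.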